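Swapping the Cyanoguanidine Tail of a Pyridazinone for Thiourea

This account rests on a few compounds, and the source may have more. Where it says the series, first, only, none or still open, it means among the compounds named here.

Within the data shown here, compound 2 `CC/N=C(/NC#N)NCCCn1nc(-c2ccccc2)ccc1=O` has the lowest of the two numbers measured so far in a functional assay on the whole organism (stomach) with Rattus norvegicus as the target (a higher number here means that more compound is needed for the effect, a lower number that less compound is needed), giving 78.3 mg/kg. Compound 1 `CC/N=C(/NC#N)NCCCCn1nc(-c2ccccc2)ccc1=O` gives 92 mg/kg in this assay, a difference that sits within the usual scatter, so the two cannot be ranked. Compound 3 `CC/N=C(\S)NCCCCn1nc(-c2ccccc2)ccc1=O` has not been measured; it differs from compound 2 as follows: a group of 7 heavy atoms (4 carbon, 2 nitrogen, 1 sulfur; no ring) in place of a group of 8 heavy atoms (4 carbon, 4 nitrogen; no ring), on a saturated chain carbon, three bonds along the chain from an aromatic nitrogen. Among the measured compounds shown here, no comparable step between measured compounds exists, so the estimated step of a 1.3-fold higher number from compound 2 to compound 3 (0.11 log units; within the scatter) is kept small, likely within the scatter. Compound 3 is therefore expected to give about 100 mg/kg, between 40 mg/kg and 250 mg/kg.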

Compound 3, dose for half-maximal effect: 37.2 mg/kg
Beside the measured number, compound 3's estimate is 2.7-fold (0.43 log units) above it; measured number outside the range, below it.
By their numbers in this assay, from the lowest: compound 3; then compounds 2 and 1 (each within the scatter of the next).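

Compounds 1 and 2 could not be ranked, but this change separates the values in this assay. With the chain kept, exchanging only the group on the amine nitrogen gives a 2.5-fold lower number from compound 1 to compound 3 (0.39 log units; beyond the scatter), while the exchange counted from the saturated chain carbon gives a 2.1-fold lower number from compound 2 to compound 3 (0.32 log units; beyond the scatter), so the thiourea compound 3 needs the least compound of the three. Nothing shown here explains this shift. Going by these compounds, it remains open whether a urea in place of the thiourea, or a longer chain, would keep this lower number.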